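This account rests on a few compounds, and the source may have more. Where it says the series, first, only, none or still open, it means among the compounds named here.

Of the compounds shown here, three have been tested in an ADME assay on MT4 cells (Homo sapiens) for cytotoxicity, read by MTT assay, with a stated time of 4 days (on this read-out lower numbers stand for higher toxicity in this test and higher numbers for lower toxicity in this test), and none of them yields a number. Compound 1 `O=c1cc(Cc2c(F)cccc2N2CCCC2)nc(N2CCCC2)[nH]1` gives only a limit, > 73000 nM. Compound 2 `Cc1c(Cc2c(F)cccc2F)nc(N(C)c2ccccc2)[nH]c1=O` also gives only a limit, > 73000 nM. Compound 3 `Cc1c(Cc2c(F)cccc2F)nc(N2CCCC2)[nH]c1=O` likewise gives only a limit, > 82000 nM, so its standing is known only as a limit and not as a measured value.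

Compound 4 `Cc1c(Cc2c(F)cccc2N2CCCC2)nc(N2CCCC2)[nH]c1=O` keeps the core of compound 3 and changes one substituent: pyrrolidin-1-yl in place of fluoro on an aromatic carbon. Pyrrolidin-1-yl takes the place of fluoro on an aromatic carbon, ortho to a large group and meta to a fluoro group.

Among the measured compounds shown here, only one measured step exists, a step that the two limits leave unreadable from compound 2 to compound 3. It is a different change, and it offers no size to carry over. The nearest guide is compound 1, which carries the same pyrrolidin-1-yl on its aromatic ring, although its core is not that of compound 4. Compound 1 still gives the limit > 73000 nM, so no step beyond the usual scatter is expected in this assay, and no direction can be foreseen. The expected change is an at least 1.1-fold lower number from compound 3 to compound 4 (0.06 log units; that floor lies within the scatter). The estimate for compound 4 is 70000 nM, with the result expected between 30000 nM and 110000 nM.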

Compound 4, half-maximal cytotoxic concentration: > 70000 nM
Compound 4: only a limit was reported (the forecaster's own chance of this, stated with the estimate: 70%); the middle value sits exactly at the limit.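

Compound 1, compound 3 and compound 4 all give only limits in this assay, and the steps from compound 3 to compound 4 and from compound 1 to compound 4 cannot be read. The compounds shown leave open at what concentration any of them harms these cells, and whether either change alters that concentration at all.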